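The source may report more compounds than this note shows. Statements on the series, on what has been measured and on what is new or still open speak of the compounds shown alone.

Measured so far:
compound 1, `C[Se]c1nc([Se]C)c2cccnc2n1`, in an ADME assay on 184B5 cells (Homo sapiens) for cytotoxicity, read by MTT assay, with a stated time of 72 h; a higher number here means a weaker inhibitor of growth, a lower number a stronger inhibitor of growth: "not determined" (no result reported);
compound 2, `[SeH]c1nc(NCc2ccccc2)c2cccnc2n1`, in this assay: 9130 nM.

Compound 2 stands alone on the numbers: it is the only compound with a single value in this assay, and compound 1 carries no figure at all, so no step from one measured compound to another can be shown here. Compound 3 is `CSc1nc(NCc2ccccc2)c2cccnc2n1`. It differs from compound 2 by a group of 2 heavy atoms (1 carbon, 1 sulfur; no ring) in place of one selenium atom, on an aromatic carbon, on an aromatic carbon of a six-membered aromatic ring with two nitrogen, part of a fused or bridged system of two rings, between two ring nitrogen atoms. Among the compounds with values here, with no measured step to lean on, the change is expected to move this assay by no more than the usual scatter, if at all, with a slight lean toward a weaker inhibitor of growth, so that compound 3 is estimated at 12000 nM, in the range 3000 nM to 50000 nM. This expectation corresponds to a 1.3-fold higher number from compound 2 to compound 3 (0.12 log units; within the scatter).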

Compound 3, concentration for total growth inhibition: > 100000 nM
Compound 3 was reported as a limit; the forecaster's own chance of this, stated with the estimate: 10%; middle value at least 8.3-fold (0.92 log units) away from the limit.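

Among the compounds with a number, only compound 2 had shown this position, carrying a single selenium atom on the aromatic carbon between two ring nitrogen atoms, so nothing yet indicated how much the read-out in this assay depended on the group there. Replacing that selenium atom with methylsulfanyl gives an at least 10-fold higher number from compound 2 to compound 3 (1.03 log units; beyond the scatter), which shows that this one change is enough to move the read-out well beyond the scatter. The value of compound 3 is a limit and not a number: the limit of > 100000 nM in this assay, at which 1 of the 3 values shown sits.

The change swaps selenium for sulfur and adds a methyl group at once, so a free thiol or a methylselanyl group at this carbon, with the rest of compound 3 kept, would be needed to separate the two. As far as these compounds go, how an amine or a longer chain such as butylsulfanyl would read at this carbon in this assay also remains open.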